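Bromo for nitro at the hydrazide end of compound 2

The compounds below may be only part of what the source reports. "The series", "measured", "known", "first", "only" and "open" are said of these compounds alone.

Measured compounds:
Compound 1 `Cc1ccc(C)n1-c1ccc(C(=O)N/N=C/c2ccc(N(C)C)cc2)cc1` — "not determined" (no result reported).
Compound 2 `O=C(NNC(=O)c1ccccc1[N+](=O)[O-])c1ccc(-n2cccc2)cc1` — 205000 nM.
Compound 3 `Cc1ccc(C)n1-c1ccc(C(=O)N/N=C/c2ccc(Br)cc2)cc1` — "not determined" (no result reported).

The study gathers three compounds tested in an ADME assay on A549 cells (Homo sapiens) for cytotoxicity, read by MTT assay, with a stated time of 72 h (on this read-out lower numbers stand for stronger inhibition and higher numbers for weaker inhibition), of which only compound 2 returned a number. In this assay, among the measured compounds shown here, compound 2 gives 205000 nM, a weak effect, and it is the only value on record; compound 1 gives "not determined" (no result reported) and compound 3 gives "not determined" (no result reported), so nothing can be said of how they compare with it, and no step between measured compounds is available.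

The unmeasured compound 4 `O=C(NNC(=O)c1ccccc1Br)c1ccc(-n2cccc2)cc1` shares the core of compound 2 and differs from it in one place: bromo in place of nitro on an aromatic carbon. The change sits on an aromatic carbon of a six-membered aromatic ring of carbon only, ortho to a large group, and swaps a nitro for a bromo.

For the measured compounds named here, with no measured step to lean on, the expectation is that this change moves the number by no more than the usual scatter of this assay, in either direction. Compound 4 is therefore expected to come in at 160000 nM, within 50000 nM to 500000 nM. The step this estimate implies is a 1.3-fold lower number from compound 2 to compound 4 (0.11 log units; within the scatter).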

Compound 4, half-maximal inhibitory concentration: 201000 nM
Compound 4: middle estimate off by 1.3-fold (0.10 log units), on the low side, and the stated range covers the measured number.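

Among the compounds shown here, the pair gives the first step that can be read in this set: in this assay the change from nitro to bromo on this aromatic carbon, ortho to a large group, amounts to a 1.0-fold lower number from compound 2 to compound 4 (0.01 log units; within the scatter). Three heavy atoms and two hydrogen-bond acceptors leave and one bromine atom enters, yet this single pair shows no difference beyond the scatter, so at this place the read-out does not separate the two groups. No evidence here bears on why the two groups read alike.

For the compounds shown here, whether an amine, a carboxylic acid or a longer chain such as propyl on this same aromatic carbon would also stay within the scatter remains open, since nitro and bromo are the only two groups compared at this place. As far as these compounds go, whether the same exchange would read alike elsewhere on the ring is also open, and compound 1 and compound 3, with no number reported, offer no further comparison.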